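The source may report more compounds than this note shows. Statements on the series, on what has been measured and on what is new or still open speak of the compounds shown alone.

Among the compounds with values here, in an ADME assay on Vero cells (Chlorocebus sabaeus) for cytotoxicity, read by resazurin assay, with a stated time of 72 h (on this read-out lower numbers stand for stronger inhibition and higher numbers for weaker inhibition), compound 2 (`COc1ccc(C(=O)CCN2CCN(c3ccc([N+](=O)[O-])cc3)CC2)cc1`) gives 587000 nM as the highest of the three numbers so far. Compound 1 (`COc1ccc(C(=O)CCN2CCN(c3ccc(C(F)(F)F)cc3)CC2)cc1`) gives 135000 nM and compound 3 (`COc1ccc(C(=O)CCN2CCN(c3ccc([N+](=O)[O-])cc3)CC2)cc1OC`) gives 105000 nM on the same read-out. Compound 4 (`O=C(CCN1CCN(c2ccc([N+](=O)[O-])cc2)CC1)c1ccc(Br)cc1`) is not yet measured. It departs from compound 2 by bromo in place of methoxy on an aromatic carbon in the form of bromo in place of methoxy on an aromatic carbon, para to a large group, that is 4-methoxyphenyl to 4-bromophenyl.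

Within the data shown here, two measured steps bear on this only indirectly. The closer one is a 5.6-fold lower number from compound 2 to compound 3 (0.75 log units; beyond the scatter) with methoxy in place of hydrogen on an aromatic carbon, on the same ring where the change to compound 4 falls. The other is a 4.3-fold higher number from compound 1 to compound 2 (0.64 log units; beyond the scatter) with nitro in place of trifluoromethyl on an aromatic carbon, on a different ring. Among the measured compounds shown here, no measured pair shows the bromo change directly. Since compound 2 at 587000 nM stands above both neighbours, a modest step towards a lower number is expected in this assay and a larger one is not. The estimated change is a 3.3-fold lower number from compound 2 to compound 4 (0.51 log units; beyond the scatter) in size. For compound 4 the expected value is 180000 nM within an estimated range from 60000 nM to 550000 nM on this read-out.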

Compound 4, half-maximal inhibitory concentration: 79800 nM
For compound 4 the middle estimate is 2.3-fold (0.35 log units) above the measured one; the measured number falls inside the stated range.
By their numbers in this assay, from the lowest: compounds 4, 3 and 1 (each within the scatter of the next); then compound 2.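

Working from the step of a 7.4-fold lower number from compound 2 to compound 4 (0.87 log units; beyond the scatter) in this assay, the group para to a large group on this ring is itself open to change, which the earlier compounds did not show: they changed this ring only by adding a second methoxy, leaving the 4-methoxy group in place. Set beside a 5.6-fold lower number from compound 2 to compound 3 (0.75 log units; beyond the scatter), the result gives two different edits on the same ring, each with the nitro-bearing ring held constant, and both give a lower number beyond the scatter, so the high number of compound 2 does not survive either edit. No measurement shown here accounts for this change from 4-methoxyphenyl to 4-bromophenyl.

Still open, as far as these compounds go, is whether the step belongs to the entering bromo or to the departing methoxy, which a chloro or an amine at this position would help to separate. Also open, from the compounds shown here alone, is whether bromo in place of methoxy gives a similar step when trifluoromethyl replaces nitro on the other ring, as in compound 1.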